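The source may hold more compounds than are shown below. What is called first, only, known or untested is meant among the compounds shown, and "the series" means these compounds.

Measured so far in a functional assay on PC-3 cells (Homo sapiens) for cytotoxicity, read by sulforhodamine B assay, with a stated time of 48 h; on this read-out lower numbers stand for stronger inhibition and higher numbers for weaker inhibition:
- compound 1, `C[C@H]1CC[C@@H]2[C@@H](OC(=O)[C@]23CC(c2ccc(Cl)cc2)=NO3)[C@]2(C)C(=O)C=C[C@@]12O`: 49000 nM
- compound 2, `C[C@H]1CC[C@@H]2[C@@H](OC(=O)[C@]23CC(c2ccc(N(C)C)cc2)=NO3)[C@]2(C)C(=O)C=C[C@@]12O`: 6300 nM

For the measured compounds named here, compound 2 stands at the lowest of the two numbers so far; its nearest neighbour is compound 1, and the one step between them, a 7.8-fold lower number from compound 1 to compound 2 (0.89 log units; beyond the scatter), is the only one to date.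

Compound 3, `Cc1ccc(C2=NO[C@]3(C2)C(=O)O[C@@H]2[C@H]3CC[C@H](C)[C@]3(O)C=CC(=O)[C@@]23C)cc1`, has not yet been measured in this assay. Its difference from compound 2 is methyl in place of dimethylamino on an aromatic carbon. Going by the values given here, the one measured step that bears on this position is a 7.8-fold lower number from compound 1 to compound 2 (0.89 log units; beyond the scatter), which shows that the group on this aromatic carbon can move the number by a modest amount. Methyl is a third group at the same place, with no measured precedent, so the direction cannot be read off a parallel step; the most defensible expectation is that compound 3 gives back part of the gain seen from compound 1 to compound 2, with a higher number than compound 2 but not reaching compound 1. The expected step is a 3.2-fold higher number from compound 2 to compound 3 (0.50 log units; beyond the scatter). For compound 3 the estimate in this assay is 20000 nM, in the range 7000 nM to 60000 nM.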

Compound 3, half-maximal inhibitory concentration: 14000 nM
Beside the measured number, compound 3's estimate is 1.4-fold (0.15 log units) above it; the range from low to high includes it.
By their numbers in this assay, from the lowest: compound 2; then compound 3; then compound 1.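

In this assay this aromatic carbon now carries three groups, and they fall on three separate levels: methyl in place of dimethylamino gives a 2.2-fold higher number from compound 2 to compound 3 (0.35 log units; beyond the scatter) and methyl in place of chloro gives a 3.5-fold lower number from compound 1 to compound 3 (0.54 log units; beyond the scatter) with both steps beyond the usual scatter. The lower number relative to chloro is therefore not confined to dimethylamino: methyl, with no nitrogen and no hydrogen-bond acceptor, keeps part of it, while compound 2 remains the strongest of the three and compound 3 sits between the other two. Nothing at hand accounts for this order of dimethylamino, then methyl, then chloro.

Among the compounds shown, the three-level order rests on a single group at each level, so it remains open where methoxy, fluoro, a primary amine or a carboxylic acid would fall at the same carbon. Going by these compounds, it also remains open whether a longer chain such as ethyl or isopropyl would follow methyl or move the number further, and whether a group larger than dimethylamino, such as morpholine, would extend the trend seen in compound 2.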